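A few compounds are considered here, and "the series" means these few. Any claim that something is new, unique, unknown or untested is made for them only; others in the source may bear on it.

Measured in a functional assay on MDA-MB-231 cells (Homo sapiens) for antiproliferative activity, read by MTT assay, with a stated time of 24 h; a higher number here means a weaker inhibitor, a lower number a stronger inhibitor:

Compound 1 `Cc1ccccc1NNC(=O)c1ccc(NS(=O)(=O)c2cnc(O)nc2O)cc1`: > 20000 nM (a limit)
Compound 2 `O=C(NNc1cccc(Cl)c1)c1ccccc1NS(=O)(=O)c1cnc(O)nc1O`: 11800 nM
Compound 3 `CCCCOc1ccc(C(=O)NNC(=O)c2ccc(NS(=O)(=O)c3cnc(O)nc3O)cc2)cc1`: 11900 nM

Among the compounds with values here, only two of these three compounds give a number in this assay. Compound 1 reaches only a limit, > 20000 nM. Compound 2 gives 11800 nM and compound 3 gives 11900 nM, and these two values lie within the scatter of each other. Neither can be placed ahead of the other, and compound 2 therefore stands level with compound 3.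

The account now follows the step from compound 2 to compound 4 `O=C(NNC(=O)c1ccccc1NS(=O)(=O)c1cnc(O)nc1O)c1ccccc1F`, which has not yet been measured. The change is (2-fluorophenyl)carbonyl in place of 3-chlorophenyl on an amine nitrogen. In words, (2-fluorophenyl)carbonyl stands in place of 3-chlorophenyl on an amine nitrogen, so the ring remains and a carbonyl is added.

No measured step between any two of these compounds is available as a guide. The nearest reference is compound 3, which also has a carbonyl on that nitrogen and gives 11900 nM. On that basis, no change beyond the scatter is expected. The estimated step is a 1.1-fold higher number from compound 2 to compound 4 (0.04 log units; within the scatter). For compound 4 the expected value is 13000 nM, with an estimated range of 6000 nM to 25000 nM.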

Compound 4, half-maximal inhibitory concentration: > 20000 nM
Compound 4: no number, only a limit; the forecaster's own chance of this, stated with the estimate: 25%; middle value at least 1.5-fold (0.18 log units) from the limit.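

In this assay, (2-fluorophenyl)carbonyl in place of 3-chlorophenyl on an amine nitrogen gives the first step that can be read among these compounds: an at least 1.6-fold higher number from compound 2 to compound 4 (0.22 log units; that floor lies within the scatter). Compound 4 reaches only a limit, so this step is a floor and not a measured size, and that floor does not by itself establish a change beyond the scatter. The true size of the step cannot be fixed because the read-out ends at a limit shared with another compound: the limit of > 20000 nM in this assay, at which 2 of the 4 values shown sit.

The change swaps the ring's substituent and adds a carbonyl in a single step, so the compounds shown do not separate the part played by the fluorine from that of the carbonyl. As far as these compounds go, it remains open whether (3-chlorophenyl)carbonyl, an unsubstituted phenylcarbonyl or a 2-fluorophenyl group attached directly on that nitrogen, or a small acetyl group there, would give a measurable number in this assay.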